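The source may report more compounds than this note shows. Statements on the series, on what has been measured and on what is new or still open speak of the compounds shown alone.

Compound 1 `CC(C)Sc1nnc(-c2c(CNC3CC3)c3ccccc3n2C)n1-c1ccccc1` is one of two compounds with a number in a physicochemical assay for lipophilicity; a lower number here means a more polar compound, a higher number a more lipophilic compound; there compound 1 gives 4.81, the lower of the two, while compound 2 `CC1CCCN(Cc2c(-c3nnc(SC(C)C)n3-c3ccccc3)n(C)c3ccc(F)cc23)C1` gives 6.18, a difference beyond the usual scatter. Compound 3 `COCCNCc1c(-c2nnc(SC(C)C)n2-c2ccccc2)n(C)c2ccccc12` is the next compound to be measured in this assay. It differs from compound 1 in one place (2-methoxyethyl in place of cyclopropyl on an amine nitrogen). Among the measured compounds shown here, with no comparable step measured, the expectation for compound 3 is a modest fall, a number 0.36 log units lower from compound 1 to compound 3 (beyond the scatter), that may or may not clear the scatter. Compound 3 is estimated at 4.45, within 3.95 to 4.95.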

Compound 3, partition coefficient: 4.36
Beside the measured number, compound 3's estimate is 0.09 log units above it; the measured number falls inside the stated range.
By their numbers in this assay, from the lowest: compound 3; then compound 1; then compound 2.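

In this assay the amine nitrogen proves sensitive to its substituent: 2-methoxyethyl in place of cyclopropyl gives a modest step (a number 0.45 log units lower from compound 1 to compound 3 (beyond the scatter)). Among the compounds shown here, this is the first comparison that changes a single place, as compound 2 differs from compound 1 in more than one. Nothing given here explains the step. From the compounds shown here alone, whether it follows the ether oxygen or the loss of the ring stays open, and a plain propyl chain on the same nitrogen could separate the two. Going by these compounds, how a hydroxyethyl group or a cyclobutyl ring would compare is also open.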